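This account rests on a few compounds, and the source may have more. Where it says the series, first, only, none or still open, it means among the compounds named here.

Compound 2 `Cc1cccc(NC(=O)c2nnc(COc3ccc(CCC(=O)O)cc3)s2)c1` gives 1770 nM in a functional assay on CHO cells for agonist activity at Free fatty acid receptor 1 (Homo sapiens), read by calcium flux (a lower number here means that less compound is needed, a higher number that more compound is needed for the effect), the highest of the two numbers measured; its nearest neighbour, compound 1 `O=C(O)CCc1ccc(OCc2nnc(C(=O)Nc3ccccc3F)s2)cc1`, gives 580 nM in this assay. Within the data shown here, the only step in hand, a 3.1-fold higher number from compound 1 to compound 2 (0.48 log units; beyond the scatter), shows that exchanging the aryl group on the amide-type nitrogen moves the number modestly. Compound 3 `Cc1ccccc1NC(=O)c1nnc(COc2ccc(CCC(=O)O)cc2)s1` differs from compound 2 by 2-methylphenyl in place of 3-methylphenyl on an amide-type nitrogen, a rearrangement with the same atoms. Among the measured compounds shown here, with no measured pair sharing this exact change, only a modest shift of similar size is expected. Compound 3 is therefore estimated at 1200 nM, between 400 nM and 3500 nM, meaning an expected step of a 1.5-fold lower number from compound 2 to compound 3 (0.17 log units; within the scatter).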

Compound 3, half-maximal effective concentration: 1520 nM
Beside the measured number, compound 3's estimate is 1.3-fold (0.10 log units) below it; the range from low to high includes it.
By their numbers in this assay, from the lowest: compound 1; then compounds 3 and 2 (each within the scatter of the next).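

In this assay the step between the two methylphenyl groups on the amide-type nitrogen (a 1.2-fold lower number from compound 2 to compound 3 (0.07 log units; within the scatter)) stays within the scatter, so compounds 2 and 3 cannot be told apart. Methyl in place of fluoro on an aromatic carbon (a 2.6-fold higher number from compound 1 to compound 3 (0.42 log units; beyond the scatter)) is a step of similar size to the earlier one and lies beyond the scatter, so both methylphenyl compounds stand apart from compound 1. No evidence here bears on these steps. Still open, as far as these compounds go, is whether a 3-fluorophenyl group would track compound 1 or compound 2. A 2-chlorophenyl group on the same nitrogen also remains to be placed among these values.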